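Replacing the Triazole Substituent in a Weak Amine Oxidase Series

This account rests on a few compounds, and the source may have more. Where it says the series, first, only, none or still open, it means among the compounds named here.

Three compounds sharing one core have been characterised in an assay for binding affinity to Amine oxidase [flavin-containing] A (Homo sapiens); on this read-out higher numbers stand for weaker inhibition and lower numbers for stronger inhibition. Compound 1 `O=Cc1cn(C[C@H]2CN(c3ccc(C4=CCS(=O)(=O)CC4)c(F)c3)C(=O)O2)nn1` carries a formyl group on the triazole and in this assay gives 3200 nM. Compound 2 `C[Si](C)(C)C#Cc1cn(C[C@H]2CN(c3ccc(C4=CCS(=O)(=O)CC4)c(F)c3)C(=O)O2)nn1` bears a trimethylsilyl-capped alkyne in place of the formyl group; in this assay compound 2 reaches only the limit > 200000 nM. Compound 3 `C#Cc1cn(C[C@H]2CN(c3ccc(C4=CCS(=O)(=O)CC4)c(F)c3)C(=O)O2)nn1` carries a bare ethynyl group, and in this assay compound 3 likewise reaches only the limit > 200000 nM. Both departures from the formyl compound were large: an at least 62-fold higher number from compound 1 to compound 2 (1.79 log units; beyond the scatter) and an at least 62-fold higher number from compound 1 to compound 3 (1.79 log units; beyond the scatter). The step between the two alkynes cannot be read, since a step that the two limits leave unreadable from compound 2 to compound 3; indeed (the limit of > 200000 nM in this assay, at which 2 of the 3 values shown sit).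

Compound 3 thus stands at the weak end of what has been measured. Compound 4 `Cc1cnnn1C[C@H]1CN(c2ccc(C3=CCS(=O)(=O)CC3)c(F)c2)C(=O)O1` differs from it by 5-methyl-1H-1,2,3-triazol-1-yl in place of 4-ethynyl-1H-1,2,3-triazol-1-yl on a saturated chain carbon bound to a saturated ring carbon. Among the measured compounds shown here, no measured step covers a methyl on the triazole, and the only informative steps show that leaving the formyl group costs activity. Compound 4 lacks that formyl group as well, so its number is expected to remain high, with the step of an at least 1.3-fold lower number from compound 3 to compound 4 (0.12 log units; that floor lies within the scatter) likely small and a fair chance of a limit again. Compound 4 is therefore estimated at 150000 nM, within 30000 nM to 600000 nM.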

Compound 4, inhibition constant: 4500 nM
Estimate against measurement, compound 4: 33-fold (1.52 log units) above; the measured number lies below the stated range.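

In this assay the step to the 5-methyl-1H-1,2,3-triazol-1-yl group is a 1.4-fold higher number from compound 1 to compound 4 (0.15 log units; within the scatter), so a compound without the formyl group can match the formyl compound within the scatter. Against the alkynes the same group gives an at least 44-fold lower number from compound 3 to compound 4 (1.64 log units; beyond the scatter) and an at least 44-fold lower number from compound 2 to compound 4 (1.64 log units; beyond the scatter), both sizes resting on limits of the assay rather than on numbers, so the large losses seen earlier go with the two alkyne groups and not with the mere absence of formyl. Compound 2 and compound 3 remain the only compounds at a limit: the limit of > 200000 nM in this assay, at which 2 of the 4 values shown sit.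

Compound 4 differs from compound 1 both in the group and in where the group sits on the triazole, as the names 5-methyl-1H-1,2,3-triazol-1-yl and 4-formyl-1H-1,2,3-triazol-1-yl show, so the compounds shown cannot separate the two changes. On these data alone, whether an amine or a carboxylic acid on the triazole would hold this level or improve on it also stays open, as does the true size of the steps from the two alkynes.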